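The source may hold more compounds than are shown below. What is called first, only, known or untested is meant among the compounds shown, and "the series" means these compounds.

Of the compounds shown here, three sharing one core have been tested in a functional assay on SF-268 cells (Homo sapiens) for inhibition, read by sulforhodamine B assay, with a stated time of 48 h, tested at 10 uM; on this read-out lower numbers stand for less inhibition and higher numbers for more inhibition at the one concentration tested (going by the name of the read-out). Compound 1 `Brc1cn2ccnc2c(-c2ccc3ncn(C4CCCCC4)c3c2)n1` gives 17.1%, compound 2 `c1ccc(-c2cn3ccnc3c(-c3ccc4ncn(C5CCCCC5)c4c3)n2)cc1` gives 21.7%, and compound 3 `c1ccc2c(-c3cn4ccnc4c(-c4ccc5ncn(C6CCCCC6)c5c4)n3)cccc2c1` gives 7.84%. Compound 2 has the highest of the three numbers, but its nearest neighbour is compound 1, and the step of a number 4.6 percentage points higher from compound 1 to compound 2 (within the scatter) lies within the scatter, so no order between them can be claimed; the step of a number 13.9 percentage points lower from compound 2 to compound 3 (beyond the scatter) is the only one beyond the scatter, and a number 9.3 percentage points lower from compound 1 to compound 3 (within the scatter) again falls within it.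

Compound 4 `CC(=O)c1ccc(-c2cn3ccnc3c(-c3ccc4ncn(C5CCCCC5)c4c3)n2)cc1` differs from compound 2 by acetyl in place of hydrogen on an aromatic carbon. Within the data shown here, none of the measured steps touches the phenyl group itself: the two steps that involve compound 2 swap the whole group at that aromatic carbon, one within the scatter and one a modest decrease. Among the measured compounds shown here, there is thus no measured step that bears directly on this change, and the record gives no ground for expecting movement beyond the scatter in this assay.

Compound 4 is therefore estimated at 20%, with a range from 5% to 35%. This estimate corresponds to an expected step of a number 1.7 percentage points lower from compound 2 to compound 4 (within the scatter).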

Compound 4, a percentage reported as inhibition, at one concentration (the size of the read-out at that concentration, not a potency): 5.01%
Compound 4: middle estimate off by 15 percentage points, on the high side; measured number inside the range.
By their numbers in this assay, from the lowest: compounds 4, 3, 1 and 2 (each within the scatter of the next, the first and the last beyond it).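

Phenyl to 4-acetylphenyl, with acetyl para to a large group, gives a number 16.7 percentage points lower from compound 2 to compound 4 (beyond the scatter) in this assay and shows that a substituent on the phenyl ring, and not only a swap of the whole group, can move this number. Compound 4 also separates from the bromo compound, with a number 12.1 percentage points lower from compound 1 to compound 4 (beyond the scatter), whereas a number 2.8 percentage points lower from compound 3 to compound 4 (within the scatter) allows no order between the 4-acetylphenyl and naphthalen-1-yl compounds. No measurement at hand explains why the acetyl group has this effect.

Going by these compounds, whether an amine or a carboxylic acid in the same place on the phenyl ring would move the number the same way remains open. Also open, on these data alone, is whether any group at this position can lift the number clearly above that of compound 2.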